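Amide substitution in a dihydroxyheptanoic acid pyrazole series

The source may hold more compounds than are shown below. What is called first, only, known or untested is meant among the compounds shown, and "the series" means these compounds.

Compound 2 `Cc1ccccc1CNC(=O)c1nn(-c2ccc(F)cc2)c(OC[C@@H](O)C[C@@H](O)CC(=O)O)c1C(C)C` is assessed in a functional assay on L6 cells (Rattus norvegicus) for inhibition (on this read-out lower numbers stand for stronger inhibition and higher numbers for weaker inhibition), where compound 2 gives 2850 nM. This is the higher of the two numbers recorded so far; compound 1 `Cc1ccc(CNC(=O)c2nn(-c3ccc(F)cc3)c(CC[C@@H](O)C[C@@H](O)CC(=O)O)c2C(C)C)cc1` gives 800 nM, and the gap between the two lies beyond the scatter of the method. For compound 3 `CC(C)c1c(C(=O)NCc2ccc(Cl)cc2)nn(-c2ccc(F)cc2)c1OC[C@@H](O)C[C@@H](O)CC(=O)O` the result in this assay is "not determined" (no result reported), so no number is available for it.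

The next compound, compound 4 `CC(C)c1c(C(=O)N(C)Cc2cccc(Cl)c2)nn(-c2ccc(F)cc2)c1OC[C@@H](O)C[C@@H](O)CC(=O)O`, differs from compound 2 at the amide: (3-chlorobenzyl)(methyl)amino in place of (2-methylbenzyl)amino on a carbonyl carbon. Among the measured compounds shown here, with no measured pair covering this change, the expectation rests on compound 2 alone. The step from compound 2 to compound 4 is expected to be a modest weakening, a 1.6-fold higher number from compound 2 to compound 4 (0.20 log units; within the scatter), plausibly beyond the scatter. Compound 4 is therefore estimated at 4500 nM in this assay, within a range from 1500 nM to 14000 nM.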

Compound 4, half-maximal inhibitory concentration: 2120 nM
The estimate for compound 4 lay 2.1-fold (0.33 log units) above the measured number; low and high end bracket the measured number.
By their numbers in this assay, from the lowest: compound 1; then compounds 4 and 2 (each within the scatter of the next).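

In this assay, (3-chlorobenzyl)(methyl)amino in place of (2-methylbenzyl)amino on a carbonyl carbon gives a 1.3-fold lower number from compound 2 to compound 4 (0.13 log units; within the scatter), so at this position, removing the amide hydrogen and introducing chlorine together leave the read-out within the scatter. No other measurement bears on this result. From the compounds shown here alone, the nitrogen methyl and the chlorine enter together in compound 4, so their separate contributions remain open. Also open, going by these compounds, is how a plain benzylamino or a phenethylamino group on this carbonyl carbon would read.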